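Benzofuranyl in Place of Ethynyl on the Nucleoside Core

This account rests on a few compounds, and the source may have more. Where it says the series, first, only, none or still open, it means among the compounds named here.

Measured compounds:
- Compound 1 `CN(C)c1ncnc2c1c(-c1ccsc1)cn2[C@@H]1O[C@H](CO)[C@@H](O)[C@H]1O`: in this study the assay gave only a limit, > 20000 nM.
- Compound 2 `C#Cc1cn([C@@H]2O[C@H](CO)[C@@H](O)[C@H]2O)c2ncnc(C)c12`: 290 nM.
- Compound 3 `C#Cc1cn([C@@H]2O[C@H](CO)[C@@H](O)[C@H]2O)c2ncnc(N(C)C)c12`: 1320 nM.

In a functional assay on HepG2 cells (Homo sapiens) for antiproliferative activity, read by XTT assay, with a stated time of 72 h (on this read-out higher numbers stand for weaker inhibition and lower numbers for stronger inhibition), compound 3 gives 1320 nM, the highest of the two actual numbers; compound 2 gives 290 nM, the gap being a 4.6-fold higher number from compound 2 to compound 3 (0.66 log units; beyond the scatter). For compound 1 the read-out is a limit of the assay, > 20000 nM, rather than a number.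

Compound 4 `CN(C)c1ncnc2c1c(-c1cc3ccccc3o1)cn2[C@@H]1O[C@H](CO)[C@@H](O)[C@H]1O` differs from compound 3 by 1-benzofuran-2-yl in place of ethynyl on an aromatic carbon. For the measured compounds named here, the only measured step that bears on this change is an at least 15-fold lower number from compound 1 to compound 3 (1.18 log units; beyond the scatter), where an aromatic ring gave way to ethynyl and the number fell sharply. Compound 4 goes the opposite way, putting a larger aromatic group back in place of ethynyl, so a large rise in the number is expected, with a fair chance that only a limit like the limit of > 20000 nM in this assay, at which 1 of the 3 values shown sits, is reported. The expected step is a 15-fold higher number from compound 3 to compound 4 (1.18 log units; beyond the scatter). Compound 4 is thus estimated at 20000 nM, within 4000 nM to 100000 nM.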

Compound 4, half-maximal inhibitory concentration: > 20000 nM
Compound 4 gave a limit, no number; the forecaster's own chance of this, stated with the estimate: 50%; the middle value sits exactly at the limit.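

Putting 1-benzofuran-2-yl in place of ethynyl on the aromatic carbon gives an at least 15-fold higher number from compound 3 to compound 4 (1.18 log units; beyond the scatter) in this assay. For the compounds shown here, until now, thiophen-3-yl was the only aromatic group at this place, so the poor result of compound 1 could have been peculiar to that one ring. Compound 4 carries a larger, two-ring aromatic group, yet compound 1 and compound 4 both end at the same limit of the assay, so the loss is no longer tied to thiophen-3-yl alone: the limit of > 20000 nM in this assay, at which 2 of the 4 values shown sit.

The step from compound 1 to compound 4 cannot be read, so these two aromatic groups cannot be ranked against each other. Also open, on these data alone, is how a group such as a nitrile, an aminomethyl or a short propyl chain would fare at this place on the core of compound 3.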